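Swapping Benzyl for Butoxy: Expected Growth Inhibition

This account rests on a few compounds, and the source may have more. Where it says the series, first, only, none or still open, it means among the compounds named here.

compound 1 `Nc1nn(C(=O)Nc2ccc(Cc3ccccc3)cc2)c2ccccc12` 12900 nM
compound 2 `COc1ccccc1NC(=O)n1nc(N)c2ccccc21` > 100000 nM
compound 3 `COc1ccc(NC(=O)Nc2n[nH]c3ccccc23)cc1` > 100000 nM

Within the data shown here, in a functional assay on A549 cells (Homo sapiens) for inhibition, read by sulforhodamine B assay, with a stated time of 48 h (a higher number here means a weaker inhibitor of growth, a lower number a stronger inhibitor of growth), compound 1 gives 12900 nM, the only number among the three values shown. Compound 2 sits at a limit of the assay, > 100000 nM. Compound 3 likewise sits at a limit, > 100000 nM. Among the measured compounds shown here, compound 1 thus holds the sole measured number, the other entries being (the limit of > 100000 nM in this assay, at which 2 of the 3 values shown sit). Compound 4 (`CCCCOc1ccc(NC(=O)n2nc(N)c3ccccc32)cc1`) differs from compound 1 by butoxy in place of benzyl on an aromatic carbon, para to a large group. For the measured compounds named here, no step between measured compounds is available, so the expectation rests on this exchange alone; a modest weakening, a 1.9-fold higher number from compound 1 to compound 4 (0.29 log units; within the scatter), is estimated. Compound 4 is therefore expected to give 25000 nM, within 8000 nM to 100000 nM.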

Compound 4, concentration for 50% growth inhibition: 23500 nM
Compound 4: middle estimate off by 1.1-fold (0.03 log units), on the high side; the measured number falls inside the stated range.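

Among these compounds, the exchange of benzyl for butoxy on an aromatic carbon, para to a large group, gives the first readable step in this assay, a 1.8-fold higher number from compound 1 to compound 4 (0.26 log units; within the scatter), so the two groups cannot be told apart here. At this position, the six-membered aromatic ring of benzyl is therefore not required for a measured number, since butoxy, which has no ring, also gives one. Nothing shown here gives a cause for this result. On these data alone, whether an amine, a carboxylic acid or a longer chain would be accepted at this position remains open.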